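Adding methyl to the nitro compound

A few compounds are considered here, and "the series" means these few. Any claim that something is new, unique, unknown or untested is made for them only; others in the source may bear on it.

In a functional assay on MIA PaCa-2 cells (Homo sapiens) for antiproliferative activity, read by sulforhodamine B assay, with a stated time of 48 h (on this read-out lower numbers stand for stronger inhibition and higher numbers for weaker inhibition), compound 3 `COc1ccc2nc(-c3ccc(N/C=C\C(=O)c4ccc(OC)c([N+](=O)[O-])c4)cc3)sc2c1` gives 23600 nM. That number lies within the scatter of compound 1 `COc1ccc2nc(-c3ccc(N/C=C\C(=O)c4ccc(OC)c(O)c4)c(C)c3)sc2c1`, which gives 17000 nM. Compound 2 `COc1ccc2nc(-c3ccc(N/C=C\C(=O)c4ccc(OC)c(F)c4)c(C)c3)sc2c1` is clearly lower at 2300 nM.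

Compound 4 `COc1ccc2nc(-c3ccc(N/C=C\C(=O)c4ccc(OC)c([N+](=O)[O-])c4)c(C)c3)sc2c1` differs from compound 3 by one change, methyl in place of hydrogen on an aromatic carbon. The new group sits ortho to a large group and meta to a 6-methoxy-1,3-benzothiazol-2-yl group.

Among the compounds with values here, no measured pair isolates this change. Within the data shown here, the only measured step, a 7.4-fold lower number from compound 1 to compound 2 (0.87 log units; beyond the scatter), is modest and exchanges hydroxy for fluoro, so it bears only indirectly. Both of its compounds carry the methyl, yet their numbers differ clearly, so the methyl alone does not set the level.

A small move to a lower number is expected, and the estimated step is a 2.0-fold lower number from compound 3 to compound 4 (0.29 log units; within the scatter), near the edge of the scatter. Compound 4 is estimated at 12000 nM, with an expected range of 4000 nM to 30000 nM.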

Compound 4, half-maximal inhibitory concentration: 23600 nM
Beside the measured number, compound 4's estimate is 2.0-fold (0.29 log units) below it; the range from low to high includes it.
By their numbers in this assay, from the lowest: compound 2; then compounds 1, 3 and 4 (each within the scatter of the next).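

In this assay, within the data shown here, methyl in place of hydrogen on this aromatic carbon gives no change at the digits printed from compound 3 to compound 4 (within the scatter) and is the first direct reading of the change: with nitro present, the methyl leaves the number where it was. With the methyl held in place, nitro in place of fluoro gives a 10-fold higher number from compound 2 to compound 4 (1.01 log units; beyond the scatter) and nitro in place of hydroxy gives a 1.4-fold higher number from compound 1 to compound 4 (0.14 log units; within the scatter) as the matching step. Among these three methyl compounds, the fluoro compound alone stands apart, and no measurement here offers an explanation for that.

Going by these compounds, neither compound 1 nor compound 2 has a partner without the methyl here, so whether the flat reading holds alongside hydroxy or fluoro stays open. Also open, on these data alone, is how an ethyl group or chlorine at the methyl position, or an amine in place of nitro, would read.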